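A few compounds are considered here, and "the series" means these few. Any claim that something is new, unique, unknown or untested is made for them only; others in the source may bear on it.

Compound 3 `COc1cc(Nc2nc3ccccc3nc2S(=O)(=O)c2ccc(Br)cc2)cc(OC)c1` is the weakest of the three compounds measured in a functional assay on PC-3 cells (Homo sapiens) for cytotoxicity, read by MTT assay, with a stated time of 72 h (on this read-out lower numbers stand for stronger inhibition and higher numbers for weaker inhibition), where compound 3 gives 18200 nM. Its closest neighbour on this read-out is compound 1 `COc1ccc(S(=O)(=O)c2nc3ccccc3nc2Nc2cccc(N)c2)cc1`, which gives 8600 nM; the furthest is compound 2 `COc1ccc(Nc2nc3ccccc3nc2S(=O)(=O)c2ccc(Br)cc2)cc1`, which gives 1110 nM. Going by the values given here, the one single-point step available runs a 16-fold higher number from compound 2 to compound 3 (1.21 log units; beyond the scatter), so exchanging the group on the nitrogen of the shared core has already moved this assay strongly once.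

Compound 4 `Nc1cccc(Nc2nc3ccccc3nc2S(=O)(=O)c2ccc(Br)cc2)c1` is built from compound 3 by the change (3-aminophenyl in place of 3,5-dimethoxyphenyl on a nitrogen on an aromatic ring). Among the compounds with values here, the step from compound 2 to compound 3 concerns the same position, but no measured pair covers the 3-aminophenyl group together with the sulfonyl aryl of compound 3. Compound 1, which carries 3-aminophenyl on the same nitrogen with a different sulfonyl aryl, sits between compound 2 and compound 3 on this assay. A move back toward lower numbers is therefore expected, of moderate size, as a step of a 3.6-fold lower number from compound 3 to compound 4 (0.56 log units; beyond the scatter). On that basis compound 4 is estimated to give 5000 nM in this assay, with a range from 1500 nM to 16000 nM.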

Compound 4, half-maximal inhibitory concentration: 9010 nM
Beside the measured number, compound 4's estimate is 1.8-fold (0.26 log units) below it, and the stated range covers the measured number.
By their numbers in this assay, from the lowest: compound 2; then compounds 1 and 4 (each within the scatter of the next); then compound 3.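

In this assay, the step of a 2.0-fold lower number from compound 3 to compound 4 (0.31 log units; beyond the scatter) and the step of an 8.1-fold higher number from compound 2 to compound 4 (0.91 log units; beyond the scatter) place the new group on the same nitrogen, so three groups at this position can now be read with the sulfonyl aryl held fixed, and 4-methoxyphenyl in compound 2 gives a lower number than either 3,5-dimethoxyphenyl or 3-aminophenyl. The change to 3-aminophenyl recovers only a modest part of the large gap opened by 3,5-dimethoxyphenyl, and compound 4 remains well short of compound 2. The step of a 1.0-fold higher number from compound 1 to compound 4 (0.02 log units; within the scatter) lies within the scatter, so with 3-aminophenyl on the nitrogen, bromo in place of methoxy on an aromatic carbon does not separate the two compounds, and nothing available explains any of these steps.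

From the compounds shown here alone, that comparison of bromo and methoxy rests on this single pair, so it remains open whether the two also match with 4-methoxyphenyl or 3,5-dimethoxyphenyl on the nitrogen. Also open, going by these compounds, is how this position would respond to a plain phenyl group, or to a phenyl group carrying a carboxylic acid or a longer amine chain.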